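Aryl exchange on the ring nitrogen: compound 4 expected

The source may report more compounds than this note shows. Statements on the series, on what has been measured and on what is new or still open speak of the compounds shown alone.

Going by the values given here, in a functional assay on NCI-H226 cells (Homo sapiens) for inhibition, read by MTT assay, with a stated time of 48 h, tested at 10 uM (on this read-out higher numbers stand for more inhibition at the one concentration tested (going by the name of the read-out) and lower numbers for less inhibition), compound 1 `COc1cc(NC(=O)Nc2cc(Nc3ccc(C(C)(C)C)cc3)ncn2)cc(OC)c1` gives 47.7%, the highest of the three numbers measured so far. Compound 2 `Cc1ccc(Nc2cc(NC(=O)Nc3c(Cl)cccc3Cl)ncn2)cc1F` gives 40.7%, a gap from compound 1 that lies within the scatter; compound 3 `COc1ccc(Br)cc1Nc1cc(NC(=O)Nc2c(Cl)cccc2Cl)ncn1` gives 33%, and its gap from compound 1 lies beyond it. Compound 4 `COc1cc(NC(=O)Nc2cc(Nc3ccc(Br)cc3OC)ncn2)cc(OC)c1` differs from compound 1 in one place: 4-bromo-2-methoxyphenyl in place of 4-(tert-butyl)phenyl on a nitrogen on an aromatic ring. Among the compounds with values here, the only measured step that bears on this is likewise an exchange of the aryl group on that nitrogen, a number 7.7 percentage points lower from compound 2 to compound 3 (within the scatter), which lay within the scatter, with a different group elsewhere in the shared core. From that one step, a small downward shift or none beyond the scatter is expected for compound 4, so a number 7.7 percentage points lower from compound 1 to compound 4 (within the scatter) is the estimated step. Compound 4 is therefore estimated at 40%, with a range from 28% to 52%.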

Compound 4, a percentage reported as inhibition, at one concentration (the size of the read-out at that concentration, not a potency): 25.7%
Beside the measured number, compound 4's estimate is 14.3 percentage points above it, outside the stated range (below it).
By their numbers in this assay, from the lowest: compounds 4, 3, 2 and 1 (each within the scatter of the next, the first and the last beyond it).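

Going by these compounds alone, on the core of compound 1, in this assay, the exchange of 4-(tert-butyl)phenyl for 4-bromo-2-methoxyphenyl on the nitrogen on an aromatic ring reads as a number 22 percentage points lower from compound 1 to compound 4 (beyond the scatter), the first single-place step to pass the scatter. This shows that the aryl group at this position can move the read-out, which the earlier exchange, a number 7.7 percentage points lower from compound 2 to compound 3 (within the scatter), did not show; the two exchanges differ in their aryl groups and in the rest of the core. Nothing on hand explains the size of the new step.

Bromine and methoxy enter together, so which of them goes with the lower number stays open. Also open, on these data alone, is how an aryl group carrying an amine or a carboxylic acid would read on this nitrogen.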